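The source may report more compounds than this note shows. Statements on the series, on what has been measured and on what is new or still open speak of the compounds shown alone.

Measured so far in an assay on isolated protein for inhibition of G protein-coupled receptor kinase 5 (Homo sapiens), read by TR-FRET, with stated times of 10 min and 1 h; on this read-out lower numbers stand for stronger inhibition and higher numbers for weaker inhibition:
Compound 1 `CN(c1ccccc1)c1ccc2oc(-c3cc(-c4cnn(C5CCNCC5)c4)cnc3N)nc2c1` gives 5050 nM.
Compound 2 `Nc1ncc(-c2cnn(C3CCNCC3)c2)cc1-c1nc2cc(Nc3ccccc3)ccc2o1` gives 3500 nM.

Compound 2 shows the lower of the two numbers, yet the step of a 1.4-fold lower number from compound 1 to compound 2 (0.16 log units; within the scatter) lies within the scatter, so the two stand level. Compound 3 `CN(C)c1ccc2oc(-c3cc(-c4cnn(C5CCNCC5)c4)cnc3N)nc2c1` differs from compound 2 by dimethylamino in place of anilino on an aromatic carbon. Going by the values given here, no measured step touches this part of the molecule; the only step at hand, hydrogen in place of methyl on that nitrogen, stayed within the scatter. The step from compound 2 to compound 3 in this assay is therefore expected to be a 1.3-fold higher number from compound 2 to compound 3 (0.11 log units; within the scatter), with no clear direction beyond the scatter. Compound 3 is estimated at 4500 nM, range 1500 nM to 14000 nM.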

Compound 3, half-maximal inhibitory concentration: 1760 nM
Compound 3: middle estimate off by 2.6-fold (0.41 log units), on the high side; measured number inside the range.
By their numbers in this assay, from the lowest: compounds 3, 2 and 1 (each within the scatter of the next, the first and the last beyond it).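

In this assay, the six-membered aromatic ring of the anilino group can go without a clear loss: dimethylamino in place of anilino gives a 2.0-fold lower number from compound 2 to compound 3 (0.30 log units; within the scatter). Going by these compounds alone, the clearer signal is a 2.9-fold lower number from compound 1 to compound 3 (0.46 log units; beyond the scatter), the only step so far beyond the scatter, with methyl in place of phenyl on the nitrogen. No evidence at hand gives a cause for either step.

Open, going by these compounds, is whether a primary amine, a methoxy group or morpholine on this aromatic carbon would extend or reverse that shift.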